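The source may report more compounds than this note shows. Statements on the series, on what has been measured and on what is new or still open speak of the compounds shown alone.

Two compounds have been measured so far in a functional assay on A549 cells (Homo sapiens) for antiproliferative activity, with a stated time of 72 h; on this read-out lower numbers stand for stronger inhibition and higher numbers for weaker inhibition:

Compound 1, `Cn1c(N2N=C(c3ccccc3)CC2c2ccccc2)nc(-c2ccccc2)c(C#N)c1=O`: 52900 nM
Compound 2, `Cn1c(N2N=C(c3ccc(Cl)cc3)CC2c2ccccc2)nc(-c2ccccc2)c(C#N)c1=O`: 26900 nM

Among the compounds with values here, of these two numbers, compound 1 has the higher one, and its only neighbour is compound 2, reached by a 2.0-fold lower number from compound 1 to compound 2 (0.29 log units; within the scatter). Compound 3, `Cn1c(N2N=C(c3ccccc3)CC2c2ccccc2)nc(-c2ccc(Cl)cc2)c(C#N)c1=O`, differs from compound 1 by chloro in place of hydrogen on an aromatic carbon. Within the data shown here, the one measured step that bears on this change is the one from compound 1 to compound 2, where a chloro group was likewise added, though on a different phenyl group; that step stayed within the scatter. Nothing measured here speaks for a larger effect when the same group is added to the other phenyl, so no step beyond the scatter is expected, at most a slight drift toward a lower number. Compound 3 is therefore estimated at 40000 nM, within 15000 nM to 100000 nM, which means an expected step of a 1.3-fold lower number from compound 1 to compound 3 (0.12 log units; within the scatter) in this assay.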

Compound 3, half-maximal inhibitory concentration: 28100 nM
The estimate for compound 3 lay 1.4-fold (0.15 log units) above the measured number; the range from low to high includes it.
By their numbers in this assay, from the lowest: compounds 2, 3 and 1 (each within the scatter of the next).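

The change from phenyl to 4-chlorophenyl at this position gives a 1.9-fold lower number from compound 1 to compound 3 (0.27 log units; within the scatter) in this assay, so a second phenyl group of the shared core has now taken a chloro without a step beyond the scatter. Within the data shown here, the earlier step, a 2.0-fold lower number from compound 1 to compound 2 (0.29 log units; within the scatter), covered only one phenyl group, and this result shows that the same small outcome also holds at a second place. No measurement given here explains why adding a chloro at either place produces no clear step.

From the compounds shown here alone, whether a group other than chloro, such as an amine, a methoxy group or a carboxylic acid, would move the number beyond the scatter at this position remains open. Going by these compounds, it is also open whether a chloro on the remaining phenyl group, or on both changed phenyl groups at once, would do so.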